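The compounds below may be only part of what the source reports. "The series", "measured", "known", "first", "only" and "open" are said of these compounds alone.

Compound 3 `O=C(O)CCCCN(Cc1ccccc1)Cc1ccc2ccccc2c1` is the point of departure. In an assay on HEK293 cells for binding affinity to Substance-K receptor (Rattus norvegicus), read by FRET, tested at 10 uM (a lower number here means less inhibition, a higher number more inhibition at the concentration tested (going by the name of the read-out)), compound 3 gives 0%, which places it level with the two other compounds measured in the same way. Compound 1 `C#CCN(Cc1ccccc1)Cc1ccc2ccccc2c1` in this assay gives 0%, and compound 2 `N#CCCCN(Cc1ccccc1)Cc1ccc2ccccc2c1` gives 0%. Every step among these three stayed flat: no change at the digits printed from compound 1 to compound 2 (within the scatter), no change at the digits printed from compound 1 to compound 3 (within the scatter) and no change at the digits printed from compound 2 to compound 3 (within the scatter).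

Compound 4 `O=C(CN(Cc1ccccc1)Cc1ccc2ccccc2c1)OCCO` differs from compound 3 in one place: (2-hydroxyethoxy)carbonyl in place of 3-carboxypropyl on a saturated chain carbon bound to an amine nitrogen. The three measured steps bear on this one, since each of them also exchanged the group on a saturated chain carbon bound to an amine nitrogen, or further along that chain, and none of them moved the read-out beyond the scatter. The shared core has so far given no inhibition whatever group sits on that chain.

Compound 4 is therefore expected to show no step beyond the scatter, no change at the digits printed from compound 3 to compound 4 (within the scatter), with the read-out estimated at 0% and a range from 0% to 12%.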

Compound 4, a percentage reported as inhibition, at one concentration (the size of the read-out at that concentration, not a potency): 0%
Compound 4: the middle estimate sits on the measured number at the digits printed; the range from low to high includes it.
By their numbers in this assay, from the lowest: compounds 1, 2, 3 and 4 (each within the scatter of the next).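

On a saturated chain carbon bound to an amine nitrogen, (2-hydroxyethoxy)carbonyl in place of 3-carboxypropyl leaves this assay flat (no change at the digits printed from compound 3 to compound 4 (within the scatter)), and the same holds in place of 2-cyanoethyl (no change at the digits printed from compound 2 to compound 4 (within the scatter)) and of ethynyl (no change at the digits printed from compound 1 to compound 4 (within the scatter)). The exchange from compound 3 keeps the count of 6 heavy atoms and 1 hydrogen-bond donor but raises the hydrogen-bond acceptors from 1 to 3, and the read-out still shows no inhibition, so this position now stays silent across four different groups. No measured evidence on these compounds bears on why the read-out stays flat.

Going by these compounds, whether a primary amine, an amide or a longer chain at this position would give any inhibition stays open. So does whether this position matters at all on a core that gives a measurable read-out.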